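Compound 3: an estimate resting on one number

The source may hold more compounds than are shown below. What is called first, only, known or untested is meant among the compounds shown, and "the series" means these compounds.

Compound 1 `O=C(CCO)N[C@@H](CO)C(=O)O`: 87%
Compound 2 `NC(=O)C(=O)N[C@@H](CO)C(=O)O`: "not determined" (no result reported)

In an ADME assay on microsomes from liver (Mus musculus) for metabolic stability, with a stated time of 30 min (on this read-out higher numbers stand for a more stable compound and lower numbers for a less stable compound), compound 1 gives 87% as its result, while compound 2 stands at "not determined" (no result reported) and so offers no number to start from. Compound 3 `O=C(N[C@@H](CO)C(=O)O)C1CC1` has yet to be measured. It is reached through cyclopropyl in place of carbamoyl on a carbonyl carbon in the structure, cyclopropyl in place of carbamoyl on a carbonyl carbon. For the measured compounds named here, no measured step is available, so the data alone do not give the size of this one. Going by the values given here, the only guide is compound 1 at 87% on this read-out. A shift from that value beyond the usual scatter is not expected in either direction, though this expectation rests on a single compound. For compound 3 the estimated result in this assay is 85% within an expected range of 65% to 100% for now.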

Compound 3, percent of the compound remaining: 21%
Compound 3: middle estimate off by 64 percentage points, on the high side; the whole stated range lies above it.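

In this assay, for the compounds shown here, the group on a carbonyl carbon whose other neighbours are amide-type nitrogen proves able to move the result strongly: cyclopropyl in place of 2-hydroxyethyl gives a number 66 percentage points lower from compound 1 to compound 3 (beyond the scatter) and is the first step in this set that can be read. So the single earlier value of compound 1 did not carry over to this change, and a small swap of one group at this position is enough to take the result well beyond the scatter. The step that starts from compound 2 cannot be read, and nothing at hand bears on why the result moves so far.

The compounds shown leave open whether this step goes with the three-membered ring itself or with the loss of the hydroxyl of the 2-hydroxyethyl group. An open-chain ethyl group or a cyclobutyl ring on the same carbonyl carbon would tell these two apart.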